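The source may report more compounds than this note shows. Statements on the series, on what has been measured and on what is new or still open speak of the compounds shown alone.

In a functional assay on HOS-TE85 cells (Homo sapiens) for inhibition, read by CCK-8 assay, with a stated time of 72 h (on this read-out higher numbers stand for weaker inhibition and lower numbers for stronger inhibition), compound 1 `CC(C)(C)c1conc1N1C(=O)CSC1c1cccc(C(=O)NCCCCc2ccccc2)c1` gives > 1000 nM, which is a limit and not a number. Compound 2 `C#Cc1cc(C(=O)NCCCCc2ccccc2)cc(C2SCC(=O)N2c2ccccc2OC)c1` gives 40.8 nM in this assay, a measured number on the shared core. Compound 3 `O=C(NCCCCc1ccccc1)c1cccc(C2SCC(=O)N2c2cccc(-c3c[nH]nn3)c2)c1` differs from compound 1 on an amide-type nitrogen in a ring: a group of 11 heavy atoms (8 carbon, 3 nitrogen; one five-membered aromatic ring with 3 hetero atoms, one six-membered aromatic ring of carbon only) in place of a group of 9 heavy atoms (7 carbon, 1 nitrogen, 1 oxygen; one five-membered aromatic ring with 2 hetero atoms), on an amide-type nitrogen in a ring. For the measured compounds named here, no measured step covers this change, so the expectation rests on compound 2 at 40.8 nM. A clear move towards stronger inhibition is expected, an estimated at least 6.6-fold lower number from compound 1 to compound 3 (0.82 log units; beyond the scatter). In this assay the estimate for compound 3 is 150 nM, expected to lie between 30 nM and 800 nM.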

Compound 3, half-maximal inhibitory concentration: 110 nM
Beside the measured number, compound 3's estimate is 1.4-fold (0.13 log units) above it; measured number inside the range.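

At the amide-type nitrogen in a ring, the group with two aromatic rings in place of the group with one gives an at least 9.0-fold lower number from compound 1 to compound 3 (0.95 log units; beyond the scatter) in this assay. Compound 1 gives > 1000 nM, which is a limit. The true size of the step therefore stays unknown because it is measured from that limit: the limit of > 1000 nM in this assay, at which 1 of the 3 values shown sits.

The compounds shown leave open whether the six-membered aromatic ring alone would account for the step. From the compounds shown here alone, it is also open how a carboxylic acid or an amine in place of the five-membered aromatic ring with 3 hetero atoms would read.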